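A few compounds are considered here, and "the series" means these few. Any claim that something is new, unique, unknown or untested is made for them only; others in the source may bear on it.

The measured compounds so far:
compound 1 `CCN1CCN(CC(=O)O[C@@H]2C[C@@H]3CC[C@@]2(C)C3(C)C)CC1`, which in an ADME assay on HEK-293T cells (Homo sapiens) for cytotoxicity, read by MTT assay, with a stated time of 48 h (a lower number here means that less compound is tolerated, a higher number that more compound is tolerated), gives 130000 nM;
compound 2 `CCN1CCN(CCCC(=O)O[C@@H]2C[C@@H]3CC[C@@]2(C)C3(C)C)CC1`, which in this assay gives 131000 nM;
compound 3 `CCOC(=O)N1CCN(CC(=O)O[C@@H]2C[C@@H]3CC[C@@]2(C)C3(C)C)CC1`, which in this assay gives 227000 nM.

Compound 3 arises from compound 1 by one change, (ethoxycarbonyl in place of ethyl on an amine nitrogen in a ring). The size of that step was a 1.7-fold higher number from compound 1 to compound 3 (0.24 log units; within the scatter), so the two numbers cannot be told apart with confidence. Compound 1 and compound 2 share the same kind of ring and ester but differ in their cores; how the two cores differ is not broken down here, and their values in this assay lie within the scatter of each other.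

Compound 4 `CCOC(=O)N1CCN(CCCC(=O)O[C@@H]2C[C@@H]3CC[C@@]2(C)C3(C)C)CC1` has not yet been measured. It arises from compound 2 by the same change, (ethoxycarbonyl in place of ethyl on an amine nitrogen in a ring), at the same place as before. Because a 1.7-fold higher number from compound 1 to compound 3 (0.24 log units; within the scatter) stayed within the scatter, the second step is expected to be small as well. Compound 4 is therefore expected to show a 1.5-fold higher number from compound 2 to compound 4 (0.18 log units; within the scatter) in this assay. For compound 4 the estimated value in this assay is 200000 nM, expected to lie between 110000 nM and 360000 nM.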

Compound 4, half-maximal cytotoxic concentration: 60400 nM
Beside the measured number, compound 4's estimate is 3.3-fold (0.52 log units) above it, and the stated range ends above it.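

In this assay, the new step is a 2.2-fold lower number from compound 2 to compound 4 (0.34 log units; beyond the scatter), a modest change beyond the usual scatter. Set beside the earlier step, ethoxycarbonyl in place of ethyl on the ring nitrogen does not give the same result on the two cores: the same change on two cores in this assay, a 1.7-fold higher number (0.24 log units; within the scatter) from compound 1 to compound 3 and a 2.2-fold lower number (0.34 log units; beyond the scatter) from compound 2 to compound 4, 3.8-fold (0.58 log units) apart, beyond the scatter of two such steps This suggests that, for these two pairs, the outcome of the change depends on the core that carries it, so a step seen on one core is a poor guide to the step on the other; it does not show why the two steps differ, and two pairs cannot establish a rule for the whole series.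

The compounds shown leave open what a third core would do with the same change, for example one with a longer chain in the ester part. They also leave open how other groups on that ring nitrogen, such as acetyl or a plain methyl, would compare with ethyl and ethoxycarbonyl on each core.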